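Three Piperidine Amides at the Limit, and a Fluorobenzyl Analogue

This account rests on a few compounds, and the source may have more. Where it says the series, first, only, none or still open, it means among the compounds named here.

compound 1, `CS(=O)(=O)c1ccc(C(=O)N2CCC(C(=O)N3CCc4ccccc43)CC2)cc1[N+](=O)[O-]`, gives > 60000 nM
compound 2, `CS(=O)(=O)c1ccc(C(=O)NCCC(=O)N2CCCc3ccccc32)cc1[N+](=O)[O-]`, gives > 60000 nM
compound 3, `Cc1ccc(N2CCN(C(=O)C3CCN(C(=O)c4ccc(S(C)(=O)=O)c([N+](=O)[O-])c4)CC3)CC2)cc1`, gives > 60000 nM

These three values come from an assay on isolated protein for inhibition of thyroid hormone receptor alpha (Homo sapiens), read by fluorescence polarization; on this read-out higher numbers stand for weaker inhibition and lower numbers for stronger inhibition. For compound 1 the result in this assay is a limit of the assay and not a number. The same holds for compound 2 and for compound 3, so that compound 1 stands nowhere in particular among them: all three sit together, because of the limit of > 60000 nM in this assay, at which 3 of the 3 values shown sit.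

Compound 4, `CN(Cc1ccccc1F)C(=O)C1CCN(C(=O)c2ccc(S(C)(=O)=O)c([N+](=O)[O-])c2)CC1`, has not yet been measured in this assay. It differs from compound 1 in one place: (2-fluorobenzyl)(methyl)amino in place of 2,3-dihydro-1H-indol-1-yl on a carbonyl carbon. Going by the values given here, no measured pair here changes one group alone, so no measured step can be used to judge the size of this change. Given that compound 1 and its two neighbours all rest at the limit, the step that the limit leaves unreadable from compound 1 to compound 4 is expected to be none beyond the scatter, with a further limit the most likely outcome. The estimate for compound 4 in this assay is therefore 80000 nM, in a range from 20000 nM to 300000 nM.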

Compound 4, half-maximal inhibitory concentration: > 60000 nM
Compound 4 was reported as a limit; the forecaster's own chance of this, stated with the estimate: 85%; the middle value lies beyond the limit too.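

In this assay no step can be read between compound 1 and compound 4, since both results are limits of the assay and not numbers: the limit of > 60000 nM in this assay, at which 4 of the 4 values shown sit.
The compounds shown leave open how strongly any of them inhibits the receptor, and whether (2-fluorobenzyl)(methyl)amino in place of 2,3-dihydro-1H-indol-1-yl changes that inhibition at all.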